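Swapping One Halogenated Aryl Group on a Shared Core

The source may report more compounds than this note shows. Statements on the series, on what has been measured and on what is new or still open speak of the compounds shown alone.

Of the compounds shown here, three built on a shared core have been tested in a functional assay on HepG2 cells (Homo sapiens) for cytotoxicity, read by MTT assay, with a stated time of 24 h; a lower number here means a stronger inhibitor, a higher number a weaker inhibitor. Compound 1 `CN1C/C(=C\c2ccc(Br)cc2)C(=O)/C(=C/c2cccc([N+](=O)[O-])c2)C1` gives 8800 nM. Compound 2 `CN1C/C(=C\c2cccc([N+](=O)[O-])c2)C(=O)/C(=C/c2ccc(Cl)cc2Cl)C1` gives 4800 nM, and compound 3 `CN1C/C(=C\c2ccc(Br)cc2)C(=O)/C(=C/c2ccc(C#N)cc2)C1` gives 4840 nM. Compound 2 differs from compound 1 by a single change, (2,4-dichlorophenyl in place of 4-bromophenyl on a double-bonded chain carbon bound to a double-bonded ring carbon), and the step of a 1.8-fold lower number from compound 1 to compound 2 (0.26 log units; within the scatter) shows what that change did. The difference between the core of compound 3 and the core of compound 1 is not broken down here; their two values simply stand side by side as given.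

Compound 4 `CN1C/C(=C\c2ccc(C#N)cc2)C(=O)/C(=C/c2ccc(Cl)cc2Cl)C1` has not yet been measured. It differs from compound 3 by 2,4-dichlorophenyl in place of 4-bromophenyl on a double-bonded chain carbon bound to a double-bonded ring carbon, the same change that separates compound 2 from compound 1, at the same place. Since the earlier step of a 1.8-fold lower number from compound 1 to compound 2 (0.26 log units; within the scatter) was small, a step of about the same size is expected here, so from compound 3 to compound 4 the expected step is a 1.6-fold lower number from compound 3 to compound 4 (0.21 log units; within the scatter). This rests on one earlier example only, so the range is kept wide. Compound 4 is therefore expected to give 3000 nM in this assay, plausibly anywhere between 1300 nM and 7000 nM.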

Compound 4, half-maximal inhibitory concentration: 6250 nM
For compound 4 the middle estimate is 2.1-fold (0.32 log units) below the measured one; the range from low to high includes it.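

In this assay the swap of 4-bromophenyl for 2,4-dichlorophenyl gives a 1.3-fold higher number from compound 3 to compound 4 (0.11 log units; within the scatter) and 4-cyanophenyl in place of 3-nitrophenyl gives a 1.3-fold higher number from compound 2 to compound 4 (0.11 log units; within the scatter) on a double-bonded chain carbon bound to a double-bonded ring carbon. Set side by side, the two cores give steps for the first swap that cannot be told apart: the same change on two cores in this assay, a 1.8-fold lower number (0.26 log units; within the scatter) from compound 1 to compound 2 and a 1.3-fold higher number (0.11 log units; within the scatter) from compound 3 to compound 4, 2.4-fold (0.37 log units) apart, within the scatter of two such steps. This shows no sign that the swap behaves differently on one core than on the other, but it does not show that the swap carries over as a real effect, as neither step can be told from the ordinary spread of repeated measurements.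

As far as these compounds go, all four compounds carry aromatic rings at this place, so what a group such as an amine or a carboxylic acid would do there stays open. Also open, from the compounds shown here alone, is whether the swap would give a step beyond the scatter on a third core.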